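Adding a Methyl to the Most Potent Ether Side Chain

This account rests on a few compounds, and the source may have more. Where it says the series, first, only, none or still open, it means among the compounds named here.

Of the compounds shown here, three sharing one core have been measured in an assay on brain for displacement of a labelled ligand from Adrenergic receptor alpha-1 (Rattus norvegicus); a higher number here means a weaker inhibitor, a lower number a stronger inhibitor. Compound 1 `CCOCCOC1CCN(c2nc(N)c3cc(OC)c(OC)cc3n2)CC1` gives 1.81 nM. Compound 2 `COc1cc2nc(N3CCC(OCC(C)OC)CC3)nc(N)c2cc1OC` gives 1.41 nM; the change a 1.3-fold lower number from compound 1 to compound 2 (0.11 log units; within the scatter) stays within the scatter. Compound 3 `CCOC(COC1CCN(c2nc(N)c3cc(OC)c(OC)cc3n2)CC1)c1ccccc1` gives 0.52 nM, the lowest of the three numbers, with the gains a 3.5-fold lower number from compound 1 to compound 3 (0.54 log units; beyond the scatter) and a 2.7-fold lower number from compound 2 to compound 3 (0.43 log units; beyond the scatter) both beyond the scatter.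

Compound 4 `CCOC(C)(COC1CCN(c2nc(N)c3cc(OC)c(OC)cc3n2)CC1)c1ccccc1` differs from compound 3 by methyl in place of hydrogen on a saturated chain carbon bound to an aromatic carbon, an oxygen on a saturated carbon and a saturated chain carbon. Within the data shown here, no measured step adds a methyl at this exact place. The nearest guide is a 1.3-fold lower number from compound 1 to compound 2 (0.11 log units; within the scatter), where a small rearrangement of a chain of this kind changed nothing beyond the scatter, while the larger additions a 3.5-fold lower number from compound 1 to compound 3 (0.54 log units; beyond the scatter) and a 2.7-fold lower number from compound 2 to compound 3 (0.43 log units; beyond the scatter) gave only modest gains. A single methyl is therefore expected to move the number little, and compound 4 is expected to show a 1.2-fold higher number from compound 3 to compound 4 (0.06 log units; within the scatter), a step inside the scatter. The estimate for compound 4 in this assay is 0.6 nM, within a range from 0.25 nM to 1.5 nM.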

Compound 4, inhibition constant: 0.15 nM
Beside the measured number, compound 4's estimate is 4.0-fold (0.60 log units) above it; the measured number lies below the stated range.
By their numbers in this assay, from the lowest: compound 4; then compound 3; then compounds 2 and 1 (each within the scatter of the next).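

In this assay, a single methyl in place of hydrogen on the saturated chain carbon bound to an aromatic carbon, an oxygen on a saturated carbon and a saturated chain carbon gives a 3.5-fold lower number from compound 3 to compound 4 (0.54 log units; beyond the scatter) in this series, which shows that this carbon, unchanged until now, is sensitive to even the smallest addition, since the step matches in size the one that phenyl gave, a 3.5-fold lower number from compound 1 to compound 3 (0.54 log units; beyond the scatter) on the same side chain. With the 1-ethoxy-1-phenylethyl group in place, the gains over the simpler chains widen to a 9.4-fold lower number from compound 2 to compound 4 (0.97 log units; beyond the scatter) and a 12-fold lower number from compound 1 to compound 4 (1.08 log units; beyond the scatter) and are the largest steps in this set. Among these compounds, no measurement at hand explains why one methyl at this carbon moves the number so far.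

The compounds shown leave open whether an ethyl or a hydroxyl group at this carbon would give a larger or smaller step than methyl. They also leave open whether methyl would give the same step on a chain without the phenyl.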